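Saturating the terminal vinyl of a triyne fatty acid

The source may report more compounds than this note shows. Statements on the series, on what has been measured and on what is new or still open speak of the compounds shown alone.

Compound 1 `C=C1C[C@]2(C(=O)O)C[C@H]1CC[C@H]2[C@]1(C)CCC[C@@](C)(C(=O)OC)[C@H]1C(=O)O`: > 10000 nM
Compound 2 `C=CCCC#CC#CC#CCCCCCCCC(=O)O`: 10000 nM

In a functional assay on MCF7 cells (Homo sapiens) for cytotoxicity, read by sulforhodamine B assay, with a stated time of 3 days (on this read-out higher numbers stand for weaker inhibition and lower numbers for stronger inhibition), compound 1 gives > 10000 nM, which is a limit of the assay and not a number. Among the measured compounds shown here, compound 2 gives 10000 nM in this assay, the only number among the two values shown. Compound 3 `CCCCC#CC#CC#CCCCCCCCC(=O)O` differs from compound 2 by ethyl in place of vinyl on a saturated chain carbon, two bonds along the chain from a triple-bonded carbon. For the measured compounds named here, no measured pair shows a step of this kind, so no step beyond the usual scatter is expected in this assay. Compound 3 is therefore estimated at 10000 nM, with a range from 4000 nM to 25000 nM, meaning an expected step of no change at the digits printed from compound 2 to compound 3 (within the scatter).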

Compound 3, half-maximal inhibitory concentration: 10000 nM
For compound 3 middle estimate and measured number coincide at the digits printed, and the stated range covers the measured number.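

In this assay the first readable step appears (no change at the digits printed from compound 2 to compound 3 (within the scatter)). At this place, on a saturated chain carbon, two bonds along the chain from a triple-bonded carbon, the double bond of the vinyl group is thus not needed to keep the value of compound 2. Compound 1 alone carries a limit, which is not a number: the limit of > 10000 nM in this assay, at which 1 of the 3 values shown sits.

As far as these compounds go, whether a longer chain or an amine at this place would move the value stays open. So does the effect of replacing the carboxylic acid with its methyl ester.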